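Cyclohexyl in place of propyl on the aromatic carbon

This account rests on a few compounds, and the source may have more. Where it says the series, first, only, none or still open, it means among the compounds named here.

Among the compounds with values here, in a functional assay on brain (Rattus norvegicus, strain Wistar) for inhibition (a higher number here means a weaker inhibitor, a lower number a stronger inhibitor), three compounds carry numbers so far. Compound 1 `CCCCc1ccc(-c2c(C)[nH]c(=O)n2C(C)C)cc1` gives 10700 nM; compound 2 `Cc1[nH]c(=O)n(C2CCCCC2)c1-c1ccccc1` gives 47600 nM; compound 3 `CCCc1ccc(-c2c(C)[nH]c(=O)n2C)cc1` gives 21500 nM. On these numbers compound 3 stands second highest of the three: compound 1 sits within the scatter of it, while compound 2 sits beyond the scatter, at the higher number. Within the data shown here, no two measured compounds differ in a single place, so no step has been computed.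

Compound 4 `Cc1[nH]c(=O)n(C)c1-c1ccc(C2CCCCC2)cc1` differs from compound 3 by cyclohexyl in place of propyl on an aromatic carbon. Without a measured step to lean on, the expected step from compound 3 to compound 4 in this assay is small, a 1.8-fold lower number from compound 3 to compound 4 (0.25 log units; within the scatter), toward a lower number if anything, and may stay within the scatter. Compound 4 is estimated at 12000 nM, in the range 4000 nM to 40000 nM.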

Compound 4, half-maximal inhibitory concentration: 10000 nM
Estimate against measurement, compound 4: 1.2-fold (0.08 log units) above, within the range that was stated.
By their numbers in this assay, from the lowest: compounds 4, 1 and 3 (each within the scatter of the next, the first and the last beyond it); then compound 2.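

Within the data shown here, this is the first step that can be read: in this assay, cyclohexyl in place of propyl on the aromatic carbon gives a 2.2-fold lower number from compound 3 to compound 4 (0.33 log units; beyond the scatter), modest but beyond the scatter. This position therefore accepts a six-membered non-aromatic ring of carbon only, with no loss of inhibition. Nothing available explains the change.

Open, going by these compounds, is whether a phenyl ring, an amine or a longer chain at this position would move the number further. Also open, on these data alone, is whether the step would hold on the core of compound 1.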